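Swapping a propyl chain for a phenyl group

The source may report more compounds than this note shows. Statements on the series, on what has been measured and on what is new or still open speak of the compounds shown alone.

Compound 3 `CCCCn1ccnc1-c1cc(OC)c(OC)c(OC)c1` has been tested in a functional assay on HCT-15 cells (Homo sapiens) for antiproliferative activity, read by MTT assay, with a stated time of 72 h; on this read-out higher numbers stand for weaker inhibition and lower numbers for stronger inhibition. In this assay compound 3 gives only a limit, > 100000 nM. Two related compounds share its core and differ from it only in the group on the saturated chain carbon bound to an aromatic nitrogen. Compound 1 `COc1cc(-c2nccn2C)cc(OC)c1OC` carries hydrogen there; in this assay compound 1 also gives a limit, > 100000 nM. Compound 2 `CCCn1ccnc1-c1cc(OC)c(OC)c(OC)c1` carries a shorter chain; in this assay compound 2 likewise gives a limit, > 100000 nM. The steps between these three, a step that the two limits leave unreadable from compound 1 to compound 2, a step that the two limits leave unreadable from compound 1 to compound 3 and a step that the two limits leave unreadable from compound 2 to compound 3, therefore cannot be sized, because all three values sit at the limit of > 100000 nM in this assay, at which 3 of the 3 values shown sit.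

Compound 4 `COc1cc(-c2nccn2Cc2ccccc2)cc(OC)c1OC` is not yet measured. It differs from compound 3 in one place: phenyl in place of propyl on a saturated chain carbon bound to an aromatic nitrogen. Within the data shown here, none of the measured steps bears directly on this change, since each of them joins two limits and shows no readable size; the changes already made at this position did not bring any value into the readable range. Compound 4 is therefore expected to stay near the same limit, with the step of a number no higher from compound 3 to compound 4 (the limit leaves the size open) expected to be small or absent, though the larger phenyl group leaves room for a different outcome. The estimate for compound 4 is 100000 nM, expected to lie between 10000 nM and 300000 nM.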

Compound 4, half-maximal inhibitory concentration: > 100000 nM
Compound 4 ended at the assay's limit; the forecaster's own chance of this, stated with the estimate: 70%; the middle value lies on the limit itself.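

In this assay compound 4 gives > 100000 nM, which is a limit and not a number. The steps from compound 1, compound 2 and compound 3 to compound 4 cannot be read, because all four compounds share one limit: the limit of > 100000 nM in this assay, at which 4 of the 4 values shown sit.

The compounds shown leave open how much activity, if any, each compound has, and whether changing this group alters it.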